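Methoxy in Place of Fluoro: What Compound 3 May Show

This account rests on a few compounds, and the source may have more. Where it says the series, first, only, none or still open, it means among the compounds named here.

Measured so far:
compound 1 `O=C(CCCCN1CCN(c2cccc(Cl)c2)CC1)Nc1ccccc1Cl`: 93.2%
compound 2 `O=C(CCCN1CCN(c2ccccc2F)CC1)Nc1ccc(Cl)cc1`: 79.2%

Of the compounds shown here, two have been measured in an assay on HEK293 cells for inhibition of Voltage-dependent T-type calcium channel subunit alpha-1G (Homo sapiens), read by patch clamp, tested at 10 uM; on this read-out higher numbers stand for more inhibition at the one concentration tested (going by the name of the read-out) and lower numbers for less inhibition. Compound 1 gives 93.2%, and compound 2 gives 79.2%. Among the measured compounds shown here, compound 2 thus stands lowest of the two numbers; its only neighbour, compound 1, lies higher by a gap beyond the usual scatter. For the measured compounds named here, the two differ in more than one place, so their values give no single step to lean on.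

Compound 3 `COc1ccccc1N1CCN(CCCC(=O)Nc2ccc(Cl)cc2)CC1` differs from compound 2 in one place: methoxy in place of fluoro on an aromatic carbon

Going by the values given here, no measured pair shows this change, so there is no step in this assay to carry over. With nothing more than the position of compound 2 to go on, the change is expected to move the number only modestly, if at all, and no direction beyond the scatter is expected. Compound 3 is therefore expected to give about 78%, in a range from 60% to 92%. This estimate means a step of a number 1.2 percentage points lower from compound 2 to compound 3 (within the scatter), expected to stay within the scatter.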

Compound 3, a percentage reported as inhibition, at one concentration (the size of the read-out at that concentration, not a potency): 84.3%
Compound 3: middle estimate off by 6.3 percentage points, on the low side, and the stated range covers the measured number.
By their numbers in this assay, from the lowest: compounds 2, 3 and 1 (each within the scatter of the next, the first and the last beyond it).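

In this assay, among the compounds shown here, methoxy in place of fluoro on an aromatic carbon gives a first step that can be read at a single place, a number 5.1 percentage points higher from compound 2 to compound 3 (within the scatter), so compound 2 and compound 3 cannot be told apart on this read-out. At this position, ortho to a large group, going from 2-fluorophenyl to 2-methoxyphenyl therefore leaves the inhibition at the one concentration tested within the usual scatter. The hydrogen-bond acceptor that enters with methoxy brings no change beyond that scatter in this one pair.

Going by these compounds, whether an amine or an ethoxy group on the same aromatic carbon would also stay within the scatter remains open, as does whether the same change would read alike on the core of compound 1. No measurement shown here bears on why this step stays so small.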